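The compounds below may be only part of what the source reports. "The series", "measured", "known", "first", "only" and "open" are said of these compounds alone.

Measured so far:
compound 1 `CCOc1cc(C(C)(C)C)ccc1C1=NC(c2ccc(Cl)cc2)C(c2ccc(Cl)cc2)N1C(=O)NCCCCCCCC(=O)Nc1ccccc1N`: 1020 nM
compound 2 `CCOc1cc(C(C)(C)C)ccc1C1=NC(c2ccc(Cl)cc2)C(c2ccc(Cl)cc2)N1C(=O)NCCCCCCCC(=O)NO`: 340 nM
compound 3 `CCOc1cc(C(C)(C)C)ccc1C1=NC(c2ccc(Cl)cc2)C(c2ccc(Cl)cc2)N1C(=O)N1CCN(Cc2ccc(C(=O)NO)cc2)CC1`: 260 nM

In an assay on isolated protein for inhibition of E3 ubiquitin-protein ligase Mdm2 (Homo sapiens), read by fluorescence polarization, with a stated time of 30 min (a lower number here means a stronger inhibitor, a higher number a weaker inhibitor), compound 3 gives 260 nM, the lowest of the three numbers, although its gap to compound 2 lies within the scatter and only the gap to compound 1 is beyond it. Compound 4 `CCOc1cc(C(C)(C)C)ccc1C1=NC(c2ccc(Cl)cc2)C(c2ccc(Cl)cc2)N1C(=O)N1CCN(c2ncc(C(=O)NO)cn2)CC1` differs from compound 3 by 5-(hydroxycarbamoyl)pyrimidin-2-yl in place of 4-(hydroxycarbamoyl)benzyl on an amine nitrogen in a ring. For the measured compounds named here, no measured step covers an exchange of this kind: the single recorded step, a 3.0-fold lower number from compound 1 to compound 2 (0.48 log units; beyond the scatter), changed a different part of the molecule, and compounds 2 and 3 differ in more than one place. Since the hydroxycarbamoyl group is kept, no step beyond the scatter is expected here. Compound 4 is therefore expected to give about 300 nM, with a likely range of 120 nM to 800 nM. This estimate means a step of a 1.2-fold higher number from compound 3 to compound 4 (0.06 log units; within the scatter), within the scatter.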

Compound 4, inhibition constant: 1050 nM
Estimate against measurement, compound 4: 3.5-fold (0.54 log units) below; measured number outside the range, above it.
By their numbers in this assay, from the lowest: compounds 3 and 2 (each within the scatter of the next); then compounds 1 and 4 (each within the scatter of the next).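

In this assay, exchanging 4-(hydroxycarbamoyl)benzyl for 5-(hydroxycarbamoyl)pyrimidin-2-yl on this ring nitrogen gives a 4.0-fold higher number from compound 3 to compound 4 (0.61 log units; beyond the scatter), so the new compound is a weaker inhibitor. Keeping the hydroxycarbamoyl group therefore does not by itself hold the number here: what carries that group matters. Nothing measured here explains this loss.

The exchange changes both the ring atoms and the benzyl link at once, so their shares remain unseparated. A 4-(hydroxycarbamoyl)phenyl group or a [5-(hydroxycarbamoyl)pyrimidin-2-yl]methyl group would each change only one of them.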